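A few compounds are considered here, and "the series" means these few. Any claim that something is new, unique, unknown or untested is made for them only; others in the source may bear on it.

Measured compounds:
compound 1 `CN(C[C@H]1Cc2c(cccc2N2CCN(C3CC3)CC2)CN1)[C@H]1CCCc2cccnc21`: 265 nm/s
compound 2 `c1cnc2c(c1)CCC[C@@H]2N(CC1CCCCC1)C[C@H]1Cc2c(cccc2N2CCNCC2)CN1`: 9 nm/s

Compound 1 `CN(C[C@H]1Cc2c(cccc2N2CCN(C3CC3)CC2)CN1)[C@H]1CCCc2cccnc21` is the better of the two measured compounds in an ADME assay for permeability, using PAMPA, at pH 7.4; on this read-out higher numbers stand for higher permeability and lower numbers for lower permeability. In this assay compound 1 gives 265 nm/s, whereas compound 2 `c1cnc2c(c1)CCC[C@@H]2N(CC1CCCCC1)C[C@H]1Cc2c(cccc2N2CCNCC2)CN1` gives 9 nm/s, a gap that lies well beyond the usual scatter. Compound 2 differs from compound 1 in more than one place, so the two values show only the combined result of those changes and no single step can be read from them.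

Compound 3 `CC(C)N1CCN(c2cccc3c2C[C@H](CN(C)[C@H]2CCCc4cccnc42)NC3)CC1` has not yet been measured. It differs from compound 1 in one place: isopropyl in place of cyclopropyl on an amine nitrogen in a ring. For the measured compounds named here, no measured pair in this set shows that same change, so its effect on permeability is unknown here. Since the change swaps one small carbon group for another of the same size on the same amine nitrogen, the step is expected to be small, most likely within the scatter and, if anything, slightly downward. Compound 3 is therefore estimated at 200 nm/s, with a range from 80 nm/s to 420 nm/s, corresponding to an expected step of a 1.3-fold lower number from compound 1 to compound 3 (0.12 log units; within the scatter).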

Compound 3, apparent permeability: 143 nm/s
The estimate for compound 3 lay 1.4-fold (0.15 log units) above the measured number; the measured number falls inside the stated range.
By their numbers in this assay, from the lowest: compound 2; then compounds 3 and 1 (each within the scatter of the next).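

For the compounds shown here, this is the first change in the set that can be read at a single place. With isopropyl in place of cyclopropyl on the amine nitrogen of the six-membered ring with 2 nitrogen, this assay shows a 1.9-fold lower number from compound 1 to compound 3 (0.27 log units; within the scatter). At this position, then, the three-membered ring of carbon can give way to a group of the same 3 heavy atoms with no ring without the step leaving the scatter, though this one pair says nothing about other groups there, and nothing measured here gives a reason for the size of the step.

Going by these compounds alone, what remains open is how far this tolerance extends on that nitrogen, since the only groups compared there differ little in size: a bare hydrogen, a longer chain such as n-butyl, a ring such as cyclohexyl, or a chain carrying a hydroxyl group or a carboxylic acid could each give a different reading. Going by these compounds, the methyl group on the other amine nitrogen of compound 1 also remains untested as a single change, as the cyclohexylmethyl group there in compound 2 comes together with a second difference, so its share of that compound's value cannot be separated.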